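Series notes: replacing the aminoethyl side chain in compound 1

The source may hold more compounds than are shown below. What is called first, only, known or untested is meant among the compounds shown, and "the series" means these compounds.

Measured compounds:
- compound 1 `COc1cc(C)c(S(=O)(=O)N(C)CCOCC(=O)N2CCN(CCN(C)C)CC2)c(C)c1`: 106 nM
- compound 2 `CN(Cc1ccc(C2=NCCN2)cc1)C(=O)COCCN(C)S(=O)(=O)c1ccc(OC(F)(F)F)cc1`: 85 nM

Both numbers come from an assay on HEK293 cells for displacement of a labelled ligand from B1 bradykinin receptor (Homo sapiens), read by scintillation counting; on this read-out higher numbers stand for weaker inhibition and lower numbers for stronger inhibition. In this assay, within the data shown here, compound 1 gives 106 nM and compound 2 gives 85 nM; the two values lie within the scatter of each other, so no order between compound 1 and compound 2 can be claimed, and the two structures differ in several places at once, so no single-point step between measured compounds is available.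

The unmeasured compound 3 `COc1cc(C)c(S(=O)(=O)N(C)CCOCC(=O)N2CCN([C@H]3CN4CCC3CC4)CC2)c(C)c1` differs from compound 1 in one place: a group of 8 heavy atoms (7 carbon, 1 nitrogen; 2 six-membered non-aromatic rings with 1 hetero atom each) in place of a group of 5 heavy atoms (4 carbon, 1 nitrogen; no ring), on an amine nitrogen in a ring. The group that leaves and the group that enters each carry one hydrogen-bond acceptor and no net charge, so the change is mainly one of size and ring count at the amine nitrogen in the ring.

With no measured step of this kind in the series, the expected step from compound 1 to compound 3 is small, a 1.4-fold lower number from compound 1 to compound 3 (0.15 log units; within the scatter), and not clearly beyond the scatter in either direction. For compound 3 in this assay the estimate is 75 nM, with a range from 20 nM to 280 nM.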

Compound 3, inhibition constant: 34 nM
Beside the measured number, compound 3's estimate is 2.2-fold (0.34 log units) above it, within the range that was stated.
By their numbers in this assay, from the lowest: compound 3; then compounds 2 and 1 (each within the scatter of the next).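

In this assay the exchange of 2-(dimethylamino)ethyl for the group with 2 six-membered non-aromatic rings, on the amine nitrogen in the ring, gives a 3.1-fold lower number from compound 1 to compound 3 (0.49 log units; beyond the scatter). Among these compounds, this is the only single-point step so far, and it shows that this position accepts a larger group with 2 rings and 1 defined stereocentre in place of an open chain, with a modest gain in inhibition that lies beyond the scatter. The leaving and entering groups have the same printed counts of hydrogen-bond donors and acceptors and the same net charge, so the step goes with size, ring count and the stereocentre taken together, and nothing at hand bears on why it occurs.

The compounds shown do not separate these three features: a longer open chain such as 3-(dimethylamino)propyl would test size without rings, and the opposite stereoisomer of the entering group would test the stereocentre. On these data alone, it also remains open whether a plain methyl on this nitrogen, with no second amine, keeps inhibition in this range.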